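A few compounds are considered here, and "the series" means these few. Any claim that something is new, unique, unknown or untested is made for them only; others in the source may bear on it.

Measured compounds in a functional assay on T47D cells (Homo sapiens) for inhibition, read by sulforhodamine B assay, with a stated time of 48 h; a higher number here means that more compound is tolerated, a lower number that less compound is tolerated:
- compound 1, `C=C1CC[C@@H]2[C@](C)(COC(C)=O)[C@H](OC(C)=O)CC[C@@]2(C)[C@H]1CC(Nc1ccc(S(=O)(=O)Nc2nccc(C)n2)cc1)C1=CCOC1=O`: in this assay compound 1 gives > 100000 nM, a limit of the assay.
- compound 2, `C=C1CC[C@@H]2[C@](C)(COC(C)=O)[C@H](OC(C)=O)CC[C@@]2(C)[C@H]1CC(Nc1ccc(S(=O)(=O)Nc2ncccn2)cc1)C1=CCOC1=O`: in this assay compound 2 gives > 100000 nM, a limit of the assay.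

Compound 2 stands only at a limit in this assay, with no number behind it. The step that the two limits leave unreadable from compound 1 to compound 2 is therefore unreadable, because the limit of > 100000 nM in this assay, at which 2 of the 2 values shown sit, holds both values.

Compound 3, `C=C1CC[C@@H]2[C@](C)(COC(C)=O)[C@H](OC(C)=O)CC[C@@]2(C)[C@H]1CC(Nc1ccc(S(=O)(=O)Nc2nccs2)cc1)C1=CCOC1=O`, differs from compound 2 by 1,3-thiazol-2-yl in place of pyrimidin-2-yl on a sulfonamide nitrogen. Going by the values given here, no measured step bears on this change; the one step available in this assay is itself unreadable. Both measured compounds sit at the same limit, so for compound 3 the expectation is that no step beyond the scatter appears in this assay, and a number no higher from compound 2 to compound 3 (the limit leaves the size open) is estimated accordingly. Compound 3 is expected to give about 100000 nM, within 30000 nM to 300000 nM, most likely again reported only as a limit.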

Compound 3, concentration lethal to 50% of the cells: > 100000 nM
Compound 3 gave a limit, no number (the forecaster's own chance of this, stated with the estimate: 85%); the middle value lies on the limit itself.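

In this assay no step can be read among compound 1, compound 2 and compound 3, as all three stand at one limit: the limit of > 100000 nM in this assay, at which 3 of the 3 values shown sit.

The compounds shown leave open how 4-methylpyrimidin-2-yl, pyrimidin-2-yl and 1,3-thiazol-2-yl on the sulfonamide nitrogen compare in this assay once a number can be read.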